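The source may report more compounds than this note shows. Statements on the series, on what has been measured and on what is new or still open speak of the compounds shown alone.

Measured compounds in an assay on CHO cells for displacement of a labelled ligand from adenosine receptor A1 (Homo sapiens), read by scintillation counting, tested at 10 uM; a lower number here means less inhibition, a higher number more inhibition at the concentration tested (going by the name of the read-out):
- compound 1 `CC(C)(C)Cc1c(-c2ccncc2)sc(N)c1C(=O)c1ccc(Cl)cc1`: 1%
- compound 2 `CC(C)(C)Cc1c(-c2ccc(Cl)cc2)sc(N)c1C(=O)c1ccc(Cl)cc1`: 1%
- compound 3 `CC(C)(C)Cc1c(-c2ccc(Cl)c(Cl)c2)sc(N)c1C(=O)c1ccc(Cl)cc1`: 1%

Compound 3 stands level with the other two: the steps of no change at the digits printed from compound 1 to compound 3 (within the scatter) and no change at the digits printed from compound 2 to compound 3 (within the scatter) both lie within the scatter, as does no change at the digits printed from compound 1 to compound 2 (within the scatter). Across these three compounds the aryl group on the aromatic carbon of the shared core has been varied without any effect on this assay showing beyond the scatter; all three sit at the bottom of the read-out.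

Compound 4 `COc1cccc(-c2sc(N)c(C(=O)c3ccc(Cl)cc3)c2CC(C)(C)C)c1` is the next member. Its change from compound 3 is 3-methoxyphenyl in place of 3,4-dichlorophenyl on an aromatic carbon. Among the compounds with values here, the steps that bear on it are the three aryl exchanges on the same aromatic carbon, no change at the digits printed from compound 1 to compound 2 (within the scatter), no change at the digits printed from compound 1 to compound 3 (within the scatter) and no change at the digits printed from compound 2 to compound 3 (within the scatter), none of which moved the read-out beyond the scatter. Within the data shown here, no measured compound in this set shows a larger inhibition, so there is nothing to suggest that a further aryl exchange would. The expected step is a number 1 percentage points higher from compound 3 to compound 4 (within the scatter), none beyond the scatter. Compound 4 is therefore estimated at 2%, with a range from 0% to 12%.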

Compound 4, a percentage reported as inhibition, at one concentration (the size of the read-out at that concentration, not a potency): 1%
Compound 4: the middle estimate sits 1 percentage points above what was measured; the measured number falls inside the stated range.
By their numbers in this assay, from the lowest: compounds 1, 2, 3 and 4 (each within the scatter of the next).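

In this assay the exchange to 3-methoxyphenyl on the aromatic carbon next to the ring sulfur gives no change at the digits printed from compound 3 to compound 4 (within the scatter) and no change at the digits printed from compound 2 to compound 4 (within the scatter) and no change at the digits printed from compound 1 to compound 4 (within the scatter) so this position remains flat across all four aryl groups. The new information is that an aryl group bearing oxygen, in place of the chlorine-bearing aryl groups of compound 2 and compound 3, also shows nothing beyond the scatter. No measurement here explains this flat read-out.

Still open, as far as these compounds go, is whether a carboxylic acid or a primary amine on this aryl ring would lift the inhibition beyond the scatter. From the compounds shown here alone, the neopentyl group, the amino group and the (4-chlorophenyl)carbonyl group are the same in all four compounds, so what a methyl group in place of neopentyl would do also remains unknown.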